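Acylating the terminal amine of compound 2 with a dithiolane chain

This account rests on a few compounds, and the source may have more. Where it says the series, first, only, none or still open, it means among the compounds named here.

In a functional assay on the whole organism (strain Fischer 344) for inhibition, with Rattus norvegicus as the target, read by paw edema, at a dose of 0.01 mmol/kg by the intraperitoneal route (a higher number here means more inhibition at the dose given (going by the name of the read-out), a lower number less inhibition), compound 2 `NCCCCCCNC(=O)c1c(O)c2ccccc2n(-c2ccccc2)c1=O` gives 68.8%. Compound 1 `Cn1c(=O)c(C(=O)NCCCCCCN)c(O)c2ccccc21` gives 68.5% in this assay, and the step of a number 0.3 percentage points higher from compound 1 to compound 2 (within the scatter) is within the scatter. Among the measured compounds shown here, compound 3 `Nc1ccccc1NC(=O)c1c(O)c2ccccc2n(-c2ccccc2)c1=O` gives 48.5%, the step of a number 20.3 percentage points lower from compound 2 to compound 3 (beyond the scatter) being the only change beyond the scatter so far. Compound 4 `O=C(CCCCC1CCSS1)NCCCCCCNC(=O)c1c(O)c2ccccc2n(-c2ccccc2)c1=O` carries a group of 11 heavy atoms (8 carbon, 1 oxygen, 2 sulfur; one five-membered non-aromatic ring with 2 hetero atoms) in place of a hydrogen atom, on an amine nitrogen. The step from compound 1 to compound 2 touched a different position and was flat; the step from compound 2 to compound 3 exchanged the whole 6-aminohexyl group, not only its terminal hydrogen, so it bears only loosely. A modest downward step or none is therefore expected, a number 8.8 percentage points lower from compound 2 to compound 4 (within the scatter). Compound 4 is estimated at 60%, in the range 45% to 75%.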

Compound 4, a percentage reported as inhibition, in the whole organism at one dose (the size of the read-out at that dose, not a potency): 50%
The estimate for compound 4 lay 10 percentage points above the measured number; low and high end bracket the measured number.
By their numbers in this assay, from the lowest: compounds 3 and 4 (each within the scatter of the next); then compounds 1 and 2 (each within the scatter of the next).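

Placing a group on the terminal amine nitrogen of compound 2 is not neutral in this assay: the group of 11 heavy atoms with its five-membered non-aromatic ring gives a number 18.8 percentage points lower from compound 2 to compound 4 (beyond the scatter). This position therefore responds to change, unlike the aromatic nitrogen, where the exchange of methyl for phenyl gave a number 0.3 percentage points higher from compound 1 to compound 2 (within the scatter). Nothing available accounts for the drop.

Which part of the added group goes with the lower number stays open: the carbonyl, the chain or the ring with its two sulfur atoms. An acetyl group on this nitrogen, or the same chain ending in a cyclopentyl ring, would separate these parts.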